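A few compounds are considered here, and "the series" means these few. Any claim that something is new, unique, unknown or untested is made for them only; others in the source may bear on it.

Measured so far:

Compound 1, `CC[C@@H]1/C=C(\C)C[C@H](C)C[C@H](OC)[C@H]2O[C@@](O)(C(=O)C(=O)N3CCCC[C@H]3C(=O)O[C@H](/C(C)=C/[C@@H]3CC[C@@H](Oc4ccc(C)cc4)[C@H](OC)C3)[C@H](C)[C@@H](O)CC1=O)[C@H](C)C[C@@H]2OC`, gives 2.7 nM in a functional assay on cells for inhibition, with Murine T-cell line (Mus musculus) as the target; a higher number here means a weaker inhibitor, a lower number a stronger inhibitor.

Compound 2, `CC[C@@H]1/C=C(\C)C[C@H](C)C[C@H](OC)[C@H]2O[C@@](O)(C(=O)C(=O)N3CCCC[C@H]3C(=O)O[C@H](/C(C)=C/[C@@H]3CC[C@@H](Oc4ccc(OC)cc4)[C@H](OC)C3)[C@H](C)[C@@H](O)CC1=O)[C@H](C)C[C@@H]2OC`, gives 1.4 nM in this assay.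

Compound 3, `CC[C@@H]1/C=C(\C)C[C@H](C)C[C@H](OC)[C@H]2O[C@@](O)(C(=O)C(=O)N3CCCC[C@H]3C(=O)O[C@H](/C(C)=C/[C@@H]3CC[C@@H](Oc4ccc(C)cc4)[C@H](O)C3)[C@H](C)[C@@H](O)CC1=O)[C@H](C)C[C@@H]2OC`, gives 6 nM in this assay.

Compound 4, `CC[C@@H]1/C=C(\C)C[C@H](C)C[C@H](OC)[C@H]2O[C@@](O)(C(=O)C(=O)N3CCCC[C@H]3C(=O)O[C@H](/C(C)=C/[C@@H]3CC[C@@H](Oc4ccc(OC)cc4)[C@H](O)C3)[C@H](C)[C@@H](O)CC1=O)[C@H](C)C[C@@H]2OC`, has not been measured. It differs from compound 3 in a single place: methoxy in place of methyl on an aromatic carbon. This change has already been made once among the measured compounds, from compound 1 to compound 2: methoxy in place of methyl on an aromatic carbon. The place of the change reads the same word for word in both pairs, so it is the same change. In this assay it produced a 1.9-fold lower number from compound 1 to compound 2 (0.29 log units; within the scatter).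

The two cores are not identical. Compound 3 differs from compound 1 as follows: hydrogen in place of methyl on an oxygen on a saturated carbon. That difference gave a 2.2-fold higher number from compound 1 to compound 3 (0.35 log units; beyond the scatter), and the value of compound 3 is the highest of the three measured numbers, further from compound 2 than from compound 1.

What compound 4 will show rests on one measured pair only. Because that pair gave a 1.9-fold lower number from compound 1 to compound 2 (0.29 log units; within the scatter), the expected step is a 1.9-fold lower number from compound 3 to compound 4 (0.27 log units; within the scatter), a shift of about the same size in the same direction, starting from the higher number of compound 3. On that basis compound 4 is estimated at 3.2 nM, with a likely range from 1.5 nM to 7 nM. A single earlier example leaves room for the step to come out within the usual scatter instead, so the range is kept wide.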

Compound 4, half-maximal inhibitory concentration: 1.2 nM
For compound 4 the middle estimate is 2.7-fold (0.43 log units) above the measured one, and the stated range ends above it.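

In this assay, methoxy in place of methyl on the aromatic ring gave a 5.0-fold lower number from compound 3 to compound 4 (0.70 log units; beyond the scatter), and this step can be set beside the earlier one on the other core: the same change on two cores in this assay, a 1.9-fold lower number (0.29 log units; within the scatter) from compound 1 to compound 2 and a 5.0-fold lower number (0.70 log units; beyond the scatter) from compound 3 to compound 4, 2.6-fold (0.41 log units) apart, within the scatter of two such steps. Hydrogen in place of methyl on the oxygen on a saturated carbon gave a 1.2-fold lower number from compound 2 to compound 4 (0.07 log units; within the scatter), and the two examples of that change can be compared in the same way: the same change on two cores in this assay, a 2.2-fold higher number (0.35 log units; beyond the scatter) from compound 1 to compound 3 and a 1.2-fold lower number (0.07 log units; within the scatter) from compound 2 to compound 4, 2.6-fold (0.41 log units) apart, within the scatter of two such steps. For each change, then, the two steps do not differ by more than the scatter of two such steps, so the data give no sign that the core alters the effect, but two pairs per change are too few to fix the size of either step or to show that it would hold on any other core in the series.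

Going by these compounds, the aryl ether is seen here only as 4-methylphenoxy and 4-methoxyphenoxy, so it remains open how other groups in that place, such as a chlorine, an amine, a carboxylic acid or a longer chain like ethoxy, would behave. The oxygen on the saturated carbon carries only hydrogen or methyl, which leaves a longer chain such as ethyl or propyl on that oxygen as a further open question.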